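Shortening the carbamate chain on a selenocyanate

The compounds below may be only part of what the source reports. "The series", "measured", "known", "first", "only" and "open" are said of these compounds alone.

Three measured compounds share an aromatic ring that carries a selenium group on one side and a carbamate on the other. Compound 1 `CC(C)COC(=O)Nc1ccc([Se][Se]c2ccc(NC(=O)OCC(C)C)cc2)cc1` joins two such units through a diselenide; in a functional assay on HT-29 cells (Homo sapiens) for cytotoxicity, read by MTT assay, with a stated time of 72 h (on this read-out higher numbers stand for lower toxicity in this test and lower numbers for higher toxicity in this test), compound 1 gives 77400 nM. Compound 2 `CC(C)COC(=O)Nc1ccc([Se]C#N)cc1` carries a selenocyanate together with an isobutyl carbamate, and in this assay compound 2 gives 63700 nM. Compound 3 `Cc1ccc(OC(=O)Nc2ccc([Se]C#N)cc2)cc1` keeps the selenocyanate but has an aromatic carbamate; in this assay compound 3 gives 68700 nM. Compound 2 has the smallest of the three numbers, yet all three lie within the usual scatter of repeated measurements, so none of them stands apart.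

Compound 4 `CCOC(=O)Nc1ccc([Se]C#N)cc1` differs from compound 2 in one place: methyl in place of isopropyl on a saturated chain carbon bound to an oxygen next to a carbonyl group. Within the data shown here, no measured pair shows this exact change. Because compound 1 at 77400 nM and compound 3 at 68700 nM stay within the scatter despite larger changes on the carbamate side, the step of a 1.1-fold lower number from compound 2 to compound 4 (0.03 log units; within the scatter) is expected to stay within the scatter as well. Compound 4 is therefore expected to give about 60000 nM in this assay, within a range from 25000 nM to 150000 nM.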

Compound 4, concentration lethal to 50% of the cells: 66600 nM
For compound 4 the middle estimate is 1.1-fold (0.05 log units) below the measured one; the range from low to high includes it.
By their numbers in this assay, from the lowest: compounds 2, 4, 3 and 1 (each within the scatter of the next).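

Among these compounds, this pair is the first one-place comparison at this position: with the selenocyanate and the rest of the core unchanged, methyl in place of isopropyl gives a 1.0-fold higher number from compound 2 to compound 4 (0.02 log units; within the scatter) in this assay. The earlier compounds shown here differed in more than one place, so they could only hint at how this chain behaves, whereas this pair isolates the change from isobutyl to ethyl on the carbamate. Here, shortening the chain leaves the read-out within the scatter, and nothing available explains this result.

The compounds shown leave open how a much longer chain, such as octyl, or a chain ending in an amine or a carboxylic acid would read in this test. They also leave open whether the change from isobutyl to ethyl would read the same in a diselenide such as compound 1.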